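A few compounds are considered here, and "the series" means these few. Any claim that something is new, unique, unknown or untested is made for them only; others in the source may bear on it.

The series is built around a shared core that carries a chloro-substituted aryl group on one side and an aryl amine on the other. Compound 1 `O=C(/C=C/c1ccc(Cl)cc1)c1ccc(NCc2ccco2)cc1` gives 404 ug/mL in an ADME assay on Vero cells (Chlorocebus sabaeus) for cytotoxicity, with a stated time of 72 h; a lower number here means that less compound is tolerated, a higher number that more compound is tolerated. Compound 2 `O=C(c1ccc(NC2CCCCC2)cc1)C1CC1c1ccc(Cl)cc1` gives 196 ug/mL in this assay. Compound 3 `CC(C)CCCC(C)Nc1ccc(C(=O)C2CC2c2ccc(Cl)cc2)cc1` shares the core of compound 2; in this assay compound 3 gives "not determined" (no result reported), so compound 3 stands nowhere on the scale shown by compounds 1 and 2.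

Compound 4 `O=C(c1ccc(NCCn2cncn2)cc1)C1CC1c1ccc(Cl)cc1` is the next step from compound 3. The difference between them is 2-(1H-1,2,4-triazol-1-yl)ethyl in place of 1,5-dimethylhexyl on a nitrogen on an aromatic ring. Among the measured compounds shown here, with no number for compound 3, there is no step in this assay to read; the expectation for compound 4 rests on compound 2, whose value in this assay is 196 ug/mL, and on the size of variation that one change of this kind might bring, which is taken here as a modest shift upward or none beyond the scatter. Compound 4 is therefore expected to give about 250 ug/mL in this assay, within a range of 110 ug/mL to 550 ug/mL.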

Compound 4, half-maximal cytotoxic concentration: 39.9 ug/mL
For compound 4 the middle estimate is 6.3-fold (0.80 log units) above the measured one, and the stated range ends above it.
By their numbers in this assay, from the lowest: compound 4; then compound 2; then compound 1.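

On a nitrogen on an aromatic ring, the group carried there proves to matter in this assay: 2-(1H-1,2,4-triazol-1-yl)ethyl in place of cyclohexyl gives a 4.9-fold lower number from compound 2 to compound 4 (0.69 log units; beyond the scatter), so less compound is tolerated with the triazole-bearing group. Among the compounds shown here, this is the first readable step at this position, as the change from 1,5-dimethylhexyl cannot be read without a number for compound 3. Nothing measured here accounts for the drop.

The compounds shown leave open whether the step follows from the triazole ring itself or from the loss of the cyclohexyl ring. From the compounds shown here alone, it also remains open whether a hydroxyethyl chain or an ethyl chain ending in morpholine on the same nitrogen would stand nearer compound 2 or compound 4 in this assay.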